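The compounds below may be only part of what the source reports. "The series", "measured", "known", "first", "only" and "open" are said of these compounds alone.

Measured compounds:
Compound 1, `CC1(C)Cc2c(sc(NC(=O)Cc3ccn[nH]3)c2C(N)=O)C(C)(C)O1`, in an assay on cells for positive allosteric modulation of Cystic fibrosis transmembrane conductance regulator variant F508del (Homo sapiens), with stated times of 10 min and 7 s, in the presence of a further agent that is not named here (a lower number here means that less compound is needed, a higher number that more compound is needed for the effect), gives 136 nM.
Compound 2, `CC1(C)Cc2c(sc(NC(=O)C(C)(C)O)c2C(N)=O)C(C)(C)O1`, in this assay gives 16 nM.

For the measured compounds named here, compound 2 holds the lowest of the two numbers measured so far; its nearest neighbour is compound 1, and the step of an 8.5-fold lower number from compound 1 to compound 2 (0.93 log units; beyond the scatter) lies beyond the scatter. The unmeasured compound 3, `CC1(C)Cc2c(sc(NC(=O)[C@@H](O)C(C)(C)C)c2C(N)=O)C(C)(C)O1`, differs from compound 2 at the same position on the shared core: 1-hydroxy-2,2-dimethylpropyl in place of 1-hydroxy-1-methylethyl on a carbonyl carbon. Going by the values given here, the one measured step, from compound 1 to compound 2, concerns the same carbonyl carbon but exchanges a ring-bearing group for a small hydroxyalkyl group, so it shows that this position tolerates change and can move the number noticeably; it does not show what a larger hydroxyalkyl group with a defined stereocentre will do. Among the compounds with values here, compound 3 keeps the hydroxy group and the carbon count grows; no measured pair tests such a growth. Compound 3 is therefore expected to stay near compound 2, with the estimated step of a 1.3-fold higher number from compound 2 to compound 3 (0.10 log units; within the scatter) judged small and its direction uncertain. The estimate for compound 3 in this assay is 20 nM, with a range from 5 nM to 80 nM.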

Compound 3, half-maximal effective concentration: 2.7 nM
Compound 3: middle estimate off by 7.4-fold (0.87 log units), on the high side; the measured number lies below the stated range.
By their numbers in this assay, from the lowest: compound 3; then compound 2; then compound 1.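

At the carbonyl carbon, in this assay, replacing 1-hydroxy-1-methylethyl with 1-hydroxy-2,2-dimethylpropyl gives a 5.9-fold lower number from compound 2 to compound 3 (0.77 log units; beyond the scatter) and so shows that the number can fall further when the hydroxyalkyl group grows while its hydroxy group stays. Measured against the ring-bearing (1H-pyrazol-5-yl)methyl group, the same 1-hydroxy-2,2-dimethylpropyl group gives a 50-fold lower number from compound 1 to compound 3 (1.70 log units; beyond the scatter) and this is the widest gap among the three compounds shown at this position. Nothing measured here bears on why the number falls in either step.

The step from compound 2 to compound 3 changes the size of the group and introduces a defined stereocentre together, so the compounds shown cannot separate these two changes, and the opposite configuration at that stereocentre remains an open comparison. Also open, going by these compounds, are whether 1-hydroxy-2-methylpropyl would give an intermediate number and whether an amine or a methoxy group could stand in place of the hydroxy group on the 2,2-dimethylpropyl chain.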